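The source may report more compounds than this note shows. Statements on the series, on what has been measured and on what is new or still open speak of the compounds shown alone.

Measured in a functional assay on NUGC-3 cells (Homo sapiens) for cytotoxicity, read by sulforhodamine B assay, with a stated time of 72 h; on this read-out lower numbers stand for stronger inhibition of growth and higher numbers for weaker inhibition of growth:
compound 1 `O=C(Nc1ccccc1O)C1CCc2ccccc2N1C(=O)c1ccccc1Cl` gives 36800 nM
compound 2 `CCCCCCCCC(=O)N1c2ccccc2CCC1C(=O)Nc1cc(C(F)(F)F)cc(C(F)(F)F)c1` gives 2230 nM
compound 3 `O=C(Nc1ccccc1C(F)(F)F)C1CCc2ccccc2N1C(=O)c1ccccc1Cl` gives 2730 nM

Among these three numbers compound 1 stands highest; compound 3 sits closest to it and compound 2 furthest, both beyond the scatter. Among the measured compounds shown here, the only single-change step recorded in the set runs from compound 1 to compound 3, a 13-fold lower number from compound 1 to compound 3 (1.13 log units; beyond the scatter), and it concerns the substituent on the aromatic carbon of the amide side, not the chlorophenylcarbonyl group.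

Compound 4 `O=C(Nc1ccccc1O)C1CCc2ccccc2N1C(=O)c1cccc(Cl)c1` is the unmeasured neighbour of compound 1. The change is 3-chlorophenyl in place of 2-chlorophenyl on a carbonyl carbon. For the measured compounds named here, no measured step touches this part of the shared core. Going by the values given here, compound 2 differs from compound 1 in more than one place, so its value shows only that a different group on the ring nitrogen can go together with a much lower number, not what moving the chlorine does. The expectation therefore rests on the absence of any evidence for a shift: in this assay compound 4 is expected to stay near compound 1, with the expected step of a 1.2-fold lower number from compound 1 to compound 4 (0.09 log units; within the scatter) lying within the scatter. Compound 4 is estimated at 30000 nM, in the range 10000 nM to 90000 nM.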

Compound 4, concentration for 50% growth inhibition: 11000 nM
Beside the measured number, compound 4's estimate is 2.7-fold (0.44 log units) above it; measured number inside the range.
By their numbers in this assay, from the lowest: compounds 2 and 3 (each within the scatter of the next); then compound 4; then compound 1.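

In this assay, the chlorine on the aromatic ring of the carbonyl group is not a silent feature: 3-chlorophenyl in place of 2-chlorophenyl on a carbonyl carbon gives a 3.3-fold lower number from compound 1 to compound 4 (0.52 log units; beyond the scatter). Among the compounds shown here, this is the first single-change step to touch this part of the molecule, and it shows that relocating one atom, with the atom count and the composition of the group unchanged, is enough to move the number beyond the scatter. Alongside a 13-fold lower number from compound 1 to compound 3 (1.13 log units; beyond the scatter), which concerns trifluoromethyl in place of hydroxy, there are now two places on the shared core where a single change goes with a lower number, and nothing on hand explains the new step.

Still open, from the compounds shown here alone, is whether the change from 2-chlorophenyl to 3-chlorophenyl gives a similar step when trifluoromethyl replaces hydroxy on the amide side, as the two changes are seen only separately. Also open, going by these compounds, is how this carbonyl substituent behaves with a phenyl carrying no chlorine, or with fluorine or methoxy in place of the chlorine.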